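Swapping Fluoro for Methoxy on a Cytotoxic Series

The source may hold more compounds than are shown below. What is called first, only, known or untested is meant among the compounds shown, and "the series" means these compounds.

Of the compounds shown here, three sharing one core have been measured in a functional assay on SH-SY5Y cells (Homo sapiens) for cytotoxicity, read by MTT assay, with stated times of 8 h, 30 min and 12 h, tested at 0.05 uM; a lower number here means a weaker effect, a higher number a stronger effect of the compound at the concentration tested. Compound 1 `N=C(NCc1ccc(O)cc1)[C@@H]1CCC(=O)N1Cc1ccccc1` gives 19.8%, compound 2 `N=C(NCc1ccc(O)cc1)[C@@H]1CCC(=O)N1Cc1ccc([N+](=O)[O-])cc1` gives 25.9%, and compound 3 `N=C(NCc1ccc(O)cc1)[C@@H]1CCC(=O)N1Cc1ccc(F)cc1` gives 35.2%. Compound 3 therefore holds the highest of the three numbers, yet its gap to compound 2 stays within the scatter, so only its separation from compound 1 counts as real.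

Compound 4 `COc1ccc(CN2C(=O)CC[C@H]2C(=N)NCc2ccc(O)cc2)cc1` has not been measured. It differs from compound 3 as follows: methoxy in place of fluoro on an aromatic carbon.

Among the measured compounds shown here, no measured step introduces a methoxy, so only indirect evidence exists. The step of a number 15.4 percentage points higher from compound 1 to compound 3 (beyond the scatter) shows that fluoro on that ring mattered, while a number 9.3 percentage points higher from compound 2 to compound 3 (within the scatter) and a number 6.1 percentage points higher from compound 1 to compound 2 (within the scatter) show that hydrogen and nitro at the same place gave numbers close to each other. Taking the fluoro away is thus expected to move the number back toward the lower pair, with the methoxy itself an unknown. Compound 4 is therefore estimated at 27%, between 14% and 42%, meaning an expected step of a number 8.2 percentage points lower from compound 3 to compound 4 (within the scatter).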

Compound 4, a percentage reported as activity, at one concentration (the size of the read-out at that concentration, not a potency): 16%
Beside the measured number, compound 4's estimate is 11 percentage points above it; measured number inside the range.
By their numbers in this assay, from the lowest: compounds 4, 1, 2 and 3 (each within the scatter of the next, the first and the last beyond it).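

Replacing fluoro with methoxy in this assay gives a number 19.2 percentage points lower from compound 3 to compound 4 (beyond the scatter), so the group on this aromatic carbon can shift the read-out even when the replacement is not hydrogen. Methoxy does not separate from the other two groups, with a number 9.9 percentage points lower from compound 2 to compound 4 (within the scatter) and a number 3.8 percentage points lower from compound 1 to compound 4 (within the scatter), which leaves compound 3 clear of compound 1 and compound 4 but not of compound 2. Nothing measured here explains why 4-fluorophenyl and 4-methoxyphenyl part in this way.

Where a chloro or an amino group on the same carbon would fall relative to fluoro and methoxy remains open. From the compounds shown here alone, each number also comes from a single concentration, so whether these gaps persist at other concentrations is unknown.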